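Cytotoxicity notes on a fluorobenzamide-to-imidazole swap

The source may report more compounds than this note shows. Statements on the series, on what has been measured and on what is new or still open speak of the compounds shown alone.

Measured so far:
compound 1 `Cn1c(-c2ccccc2)cnc1NC(=O)c1ccc(F)cc1`: > 100000 nM
compound 2 `COc1cccc(-c2cnc(NC(=O)c3ccc(F)cc3)n2C)c1`: > 100000 nM
compound 3 `COc1ccc(-c2cnc(NC(=O)c3ccc(F)cc3)n2C)cc1`: >= 50000 nM

In a toxicity assay on THP-1 cells (Homo sapiens) for inhibition (a higher number here means that more compound is tolerated, a lower number that less compound is tolerated), compound 1 is recorded only as a limit, > 100000 nM, not as a number. The same holds for compound 2, at the limit of > 100000 nM in this assay, at which 2 of the 3 values shown sit. Compound 3 likewise stands at a limit, (the limit of >= 50000 nM in this assay, at which 1 of the 3 values shown sits). The steps a step that the two limits leave unreadable from compound 1 to compound 2, a step that the two limits leave unreadable from compound 1 to compound 3 and a step that the two limits leave unreadable from compound 2 to compound 3 all sit between limits and give no readable size; none of them touches the amide side of the core anyway. Compound 4 `Cn1c(-c2ccccc2)cnc1NC(=O)c1ncc[nH]1` differs from compound 1 by 1H-imidazol-2-yl in place of 4-fluorophenyl on a carbonyl carbon. Going by the values given here, no measured step speaks to this change, so no step beyond the scatter is expected: a number no higher from compound 1 to compound 4 (the limit leaves the size open). Compound 4 is therefore expected at 100000 nM, estimated between 40000 nM and 300000 nM, most likely reported again as a limit.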

Compound 4, half-maximal cytotoxic concentration: > 100000 nM
Compound 4: no number, only a limit; the forecaster's own chance of this, stated with the estimate: 80%; the middle value sits exactly at the limit.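

Compound 4 is again recorded only as a limit, > 100000 nM. Set against compound 1, itself a limit, it yields no readable step. The compounds shown leave open whether replacing 4-fluorophenyl with 1H-imidazol-2-yl changes tolerance at all in this assay.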